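The source may report more compounds than this note shows. Statements on the series, on what has been measured and on what is new or still open speak of the compounds shown alone.

In a functional assay on BT-549 cells (Homo sapiens) for inhibition, read by sulforhodamine B assay, with a stated time of 48 h, tested at 10 uM (a lower number here means less inhibition, a higher number more inhibition at the concentration tested (going by the name of the read-out)), compound 1 `c1ccc(-c2cn3ccnc3c(-c3ccc4ncn(C5CCCCC5)c4c3)n2)cc1` gives 57.1%. In this assay, compound 2 `O=Cc1ccc(-c2cn3ccnc3c(-c3ccc4ncn(C5CCCCC5)c4c3)n2)cc1` gives 33.8%.

Among the measured compounds shown here, compound 2 stands lowest of the two numbers measured so far; the nearest, compound 1, is higher, and the single measured step shows a fall of a number 23.3 percentage points lower from compound 1 to compound 2 (beyond the scatter), beyond the scatter but modest, when a formyl group is placed where compound 1 carries hydrogen.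

Compound 3 `Fc1ccc(-c2cn3ccnc3c(-c3ccc4ncn(C5CCCCC5)c4c3)n2)cc1` has not yet been measured. It differs from compound 2 as follows: fluoro in place of formyl on an aromatic carbon. For the measured compounds named here, the only measured step that bears on this change is the one from compound 1 to compound 2, since it too concerns the same position on the phenyl ring, and it says that the formyl group costs inhibition. Going by the values given here, compound 3 removes that formyl group, so part of that loss may be recovered, but no measured compound carries fluoro, so what the fluoro group adds or takes away is unknown. The expected step in this assay is therefore a rise of a number 13.2 percentage points higher from compound 2 to compound 3 (beyond the scatter), with compound 3 expected to land between compound 2 and compound 1. For compound 3 the estimated value in this assay is 47%, within a range from 30% to 64%.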

Compound 3, a percentage reported as inhibition, at one concentration (the size of the read-out at that concentration, not a potency): 20.3%
Compound 3: middle estimate off by 26.7 percentage points, on the high side; measured number outside the range, below it.
By their numbers in this assay, from the lowest: compound 3; then compound 2; then compound 1.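

Replacing the 4-formylphenyl group with 4-fluorophenyl in this assay does not recover the inhibition lost with formyl; it gives a number 13.5 percentage points lower from compound 2 to compound 3 (beyond the scatter). Set against hydrogen on the same aromatic carbon, fluoro gives a number 36.8 percentage points lower from compound 1 to compound 3 (beyond the scatter), so both substituents seen at this position fall short of hydrogen, and fluoro falls further than formyl. The order therefore does not follow the number of heavy atoms, since fluoro, with fewer heavy atoms than formyl, gives the lowest number of the three, and nothing available here accounts for this order.

Going by these compounds, it remains open whether any group on this carbon, such as an amine, a carboxylic acid or a methoxy group, could match or exceed hydrogen, or whether every replacement lowers the number. Among the compounds shown here, each compound also has only a single reading at one concentration, so the three numbers give the size of the effect at that concentration and leave open how the compounds would rank by potency.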